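Working notes: fluoro to methoxy on the phenyl group

The source may report more compounds than this note shows. Statements on the series, on what has been measured and on what is new or still open speak of the compounds shown alone.

compound 1 `Nc1ncnn2c([C@@H]3O[C@H](CO)[C@@H](O)[C@H]3O)cc(C#CC3CC3)c12`: 80 nM
compound 2 `Nc1ncnn2c([C@@H]3O[C@H](CO)[C@@H](O)[C@H]3O)cc(C#Cc3cccs3)c12`: 26600 nM
compound 3 `Nc1ncnn2c([C@@H]3O[C@H](CO)[C@@H](O)[C@H]3O)cc(-c3ccc(F)cc3)c12`: 55500 nM

In a functional assay on NCI-H460 cells (Homo sapiens) for antiproliferative activity, with a stated time of 72 h (a higher number here means a weaker inhibitor, a lower number a stronger inhibitor), compound 3 has the highest number of the three at 55500 nM, which makes it the weakest inhibitor measured so far. The next structure is compound 4 `COc1ccc(-c2cc([C@@H]3O[C@H](CO)[C@@H](O)[C@H]3O)n3ncnc(N)c23)cc1`, with methoxy in place of fluoro on an aromatic carbon, para to a large group: methoxy in place of fluoro on an aromatic carbon. The same difference reads 4-fluorophenyl to 4-methoxyphenyl.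

Among the compounds with values here, no measured pair tests this exchange directly. The closest evidence is the modest 2.1-fold higher number from compound 2 to compound 3 (0.32 log units; beyond the scatter), which separates two compounds without the cyclopropyl group. The two large steps, a 330-fold higher number from compound 1 to compound 2 (2.52 log units; beyond the scatter) and a 690-fold higher number from compound 1 to compound 3 (2.84 log units; beyond the scatter), both take that group away, so among the three compounds the low number belongs to compound 1 alone. Compound 4 also lacks cyclopropyl and keeps the phenyl, so a step of that large size is not expected in this assay. A small step is expected instead, within the scatter or near the modest one, and the data fix no firm direction. The estimated step is a 1.2-fold lower number from compound 3 to compound 4 (0.09 log units; within the scatter). For compound 4 the expected value is 45000 nM, with an estimated range of 15000 nM to 100000 nM.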

Compound 4, half-maximal inhibitory concentration: 69300 nM
Compound 4: the middle estimate sits 1.5-fold (0.19 log units) below what was measured; the measured number falls inside the stated range.
By their numbers in this assay, from the lowest: compound 1; then compound 2; then compounds 3 and 4 (each within the scatter of the next).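

In this assay, within the data shown here, the exchange of fluoro for methoxy on an aromatic carbon, para to a large group, gives the first direct reading at this position (a 1.2-fold higher number from compound 3 to compound 4 (0.10 log units; within the scatter)), so the two groups cannot be told apart here. Compound 4 stays separated from the thiophen-2-yl alkyne by a modest step (a 2.6-fold higher number from compound 2 to compound 4 (0.42 log units; beyond the scatter)) and from the cyclopropyl alkyne by a large one (an 870-fold higher number from compound 1 to compound 4 (2.94 log units; beyond the scatter)), which leaves compound 1 alone at the low end among the four compounds. Nothing measured on these compounds accounts for the flat response to this exchange.

As far as these compounds go, it remains open whether this insensitivity holds for other groups at the same place on the phenyl, such as an amine or a carboxylic acid, since fluoro and methoxy are the only two compared there. From the compounds shown here alone, it is also open whether the low number of compound 1 is specific to cyclopropyl on the triple bond or would persist with a cyclobutyl group or a longer chain such as n-butyl.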